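The source may report more compounds than this note shows. Statements on the series, on what has been measured and on what is new or still open speak of the compounds shown alone.

Compound 1 `Cc1ccccc1-n1cc(-c2ccccc2NS(=O)(=O)c2c[nH]c(=O)[nH]c2=O)nn1`: 9570 nM
Compound 2 `Cc1cccc(-n2cc(-c3ccccc3NS(=O)(=O)c3c[nH]c(=O)[nH]c3=O)nn2)c1`: 3510 nM
Compound 3 `O=c1[nH]cc(S(=O)(=O)Nc2ccccc2-c2cn(-c3ccccc3F)nn2)c(=O)[nH]1`: 10800 nM

These three compounds share one core and differ only in the aryl group on an aromatic nitrogen. In a functional assay on SGC-7901 cells (Homo sapiens) for antiproliferative activity, read by MTT assay, with a stated time of 24 h (a lower number here means a stronger inhibitor, a higher number a weaker inhibitor), compound 1 gives 9570 nM, which places it second highest of the three numbers; compound 3 sits nearest, and compound 2 furthest. The step of a 2.7-fold lower number from compound 1 to compound 2 (0.44 log units; beyond the scatter) shows that shifting the methyl from the 2-position to the 3-position lowers the number beyond the scatter, while the step of a 1.1-fold higher number from compound 1 to compound 3 (0.05 log units; within the scatter) shows that replacing the methyl with fluoro at the 2-position changes nothing beyond the scatter. Read together, a 3.1-fold higher number from compound 2 to compound 3 (0.49 log units; beyond the scatter) confirms the same picture from the other side.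

Compound 4 `O=c1[nH]cc(S(=O)(=O)Nc2ccccc2-c2cn(-c3cccc(F)c3)nn2)c(=O)[nH]1` has not yet been measured. It differs from compound 1 by 3-fluorophenyl in place of 2-methylphenyl on an aromatic nitrogen. This change combines both measured moves: the 2-position to 3-position shift seen in a 2.7-fold lower number from compound 1 to compound 2 (0.44 log units; beyond the scatter) and the methyl-to-fluoro swap seen in a 1.1-fold higher number from compound 1 to compound 3 (0.05 log units; within the scatter). Since the position shift mattered and the swap did not, a modest drop in the number is expected, of roughly the size a 2.4-fold lower number from compound 1 to compound 4 (0.38 log units; beyond the scatter). Compound 4 is therefore estimated at 4000 nM in this assay, in a range from 1500 nM to 10000 nM.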

Compound 4, half-maximal inhibitory concentration: > 20000 nM
Compound 4 ended at the assay's limit (the forecaster's own chance of this, stated with the estimate: 5%); middle value at least 5.0-fold (0.69 log units) away from the limit.
By their numbers in this assay, from the lowest: compound 2; then compounds 1 and 3 (each within the scatter of the next). At a limit, above all of these: compound 4.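

In this assay compound 4 gives > 20000 nM, which is a limit of the assay and not a number. Even so, the 3-fluorophenyl group stands apart from the earlier aryl groups, with an at least 2.0-fold higher number from compound 1 to compound 4 (0.32 log units; beyond the scatter), while an at least 1.8-fold higher number from compound 3 to compound 4 (0.26 log units; that floor lies within the scatter) gives a floor that alone does not separate the two fluoro compounds. Fluoro in place of methyl meant little between 2-methylphenyl and 2-fluorophenyl but a great deal between 3-methylphenyl and 3-fluorophenyl, with an at least 5.6-fold higher number from compound 2 to compound 4 (0.75 log units; beyond the scatter), and the earlier compounds gave no sign that the same swap could behave so differently on the two aryl groups: the same change on two cores in this assay, a 1.1-fold higher number (0.05 log units; within the scatter) from compound 1 to compound 3 and an at least 5.6-fold higher number (0.75 log units; beyond the scatter) from compound 2 to compound 4, at least 5.0-fold (0.70 log units) apart, beyond the scatter of two such steps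

From the compounds shown here alone, the true value of compound 4 remains unknown, and with it the full size of each of these steps. The compounds shown carry only methyl or fluoro on the aryl ring, which leaves open how a chlorine, a methoxy group, an amine or a carboxylic acid in that place would compare on the shared core.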